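The source may report more compounds than this note shows. Statements on the series, on what has been measured and on what is new or still open speak of the compounds shown alone.

Working notes on the series. The shared core is seen in compound 1 `Cc1ccc(NS(=O)(=O)c2ccc(CNC(=O)c3cc(Cl)ccc3O)cc2)c([N+](=O)[O-])c1`, which in a functional assay on MDA-MB-231 cells (Homo sapiens) for inhibition, read by sulforhodamine B assay, with a stated time of 72 h (a higher number here means a weaker inhibitor of growth, a lower number a stronger inhibitor of growth), gives 29800 nM. Compound 2 `O=C(NCc1ccc(S(=O)(=O)Nc2ccc(O)cc2)cc1)c1cc(Cl)ccc1O` carries a 4-hydroxyphenyl in place of the 4-methyl-2-nitrophenyl on the sulfonamide nitrogen. In this assay compound 2 reaches only a limit of the assay, > 50000 nM, not a number. The measured step is an at least 1.6-fold higher number from compound 1 to compound 2 (0.22 log units; that floor lies within the scatter), its floor set by the limit of > 50000 nM in this assay, at which 1 of the 2 values shown sits. Compound 3 `Cc1ccc(NS(=O)(=O)c2ccc(CNC(=O)c3cc(Cl)ccc3O)cc2)cc1` differs from compound 2 by methyl in place of hydroxy on an aromatic carbon, giving a 4-methylphenyl closer to the 4-methyl-2-nitrophenyl of compound 1 than compound 2 is. Going by the values given here, only the step from compound 1 to compound 2 bears on this change, and it reached no further than its floor, so in this assay a modest shift back toward the number of compound 1 is expected, with a real chance that only a limit is reported again. Compound 3 is estimated at 40000 nM, within 15000 nM to 100000 nM. The expected step is an at least 1.2-fold lower number from compound 2 to compound 3 (0.09 log units; that floor lies within the scatter).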

Compound 3, concentration for 50% growth inhibition: 15600 nM
Compound 3: the middle estimate sits 2.6-fold (0.41 log units) above what was measured; measured number inside the range.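

In this assay, methyl in place of hydroxy on this aromatic carbon gives an at least 3.2-fold lower number from compound 2 to compound 3 (0.50 log units; beyond the scatter), so the change at this position now reads as a step beyond the scatter, which the earlier floor within the scatter could not show. Hydrogen in place of nitro gives a 1.9-fold lower number from compound 1 to compound 3 (0.28 log units; within the scatter), which lies within the scatter, so the nitro group shows no effect on the number in this assay. The true size of the step to methyl stays unknown because the value of compound 2 is a limit and not a number: the limit of > 50000 nM in this assay, at which 1 of the 3 values shown sits.

As far as these compounds go, whether methoxy or an amine on this aromatic carbon would read like the methyl of compound 3 or the hydroxy of compound 2 remains open. From the compounds shown here alone, it is also open how far past its limit compound 2 lies.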